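Swapping a Chloropropyl Tail for a Cyclopentyl Ring

The source may hold more compounds than are shown below. What is called first, only, known or untested is meant among the compounds shown, and "the series" means these compounds.

Measured in a functional assay on M21 cells (Homo sapiens) for antiproliferative activity, read by sulforhodamine B assay, with a stated time of 48 h; a lower number here means a stronger inhibitor, a higher number a weaker inhibitor:
compound 1 `CCC(=O)Nc1ccc(S(=O)(=O)Oc2ccccc2C(C)C)cc1` gives 11000 nM
compound 2 `CC(C)c1ccccc1OS(=O)(=O)c1ccc(NC(=O)NCCCCl)cc1` gives 9300 nM

Within the data shown here, compound 2 holds the lowest of the two numbers, but its only neighbour, compound 1, sits within the scatter of it, so the two cannot be told apart. Among the measured compounds shown here, the one measured step, a 1.2-fold lower number from compound 1 to compound 2 (0.07 log units; within the scatter), exchanged an ethyl on the carbonyl carbon for a (3-chloropropyl)amino group and left the number essentially where it was.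

Compound 3 `CC(C)c1ccccc1OS(=O)(=O)c1ccc(NC(=O)NC2CCCC2)cc1` differs from compound 2 in one place: cyclopentyl in place of 3-chloropropyl on an amide-type nitrogen. Cut one bond further out, this reads (3-chloropropyl)amino to cyclopentylamino. For the measured compounds named here, no measured pair shows what such an exchange does; the single step available replaced a different group on the carbonyl carbon, and it stayed within the scatter. With nothing pointing to a shift in either direction, the expectation for compound 3 is a number close to that of compound 2, with a 1.0-fold lower number from compound 2 to compound 3 (0.01 log units; within the scatter) expected to stay within the scatter. Compound 3 is therefore estimated at 9000 nM, in the range 4000 nM to 20000 nM.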

Compound 3, half-maximal inhibitory concentration: 6100 nM
The estimate for compound 3 lay 1.5-fold (0.17 log units) above the measured number, within the range that was stated.
By their numbers in this assay, from the lowest: compounds 3, 2 and 1 (each within the scatter of the next).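

In this assay, exchanging the open 3-chloropropyl chain on the amide-type nitrogen for cyclopentyl, which brings in a five-membered non-aromatic ring of carbon only and removes the chlorine, gives a 1.5-fold lower number from compound 2 to compound 3 (0.18 log units; within the scatter). This place on the molecule can therefore carry a ring instead of a chain without the number leaving the scatter, and the comparison with the ethyl group on the carbonyl carbon, a 1.8-fold lower number from compound 1 to compound 3 (0.26 log units; within the scatter), also stays within the scatter, so none of the three groups can be ranked above another. Nothing measured here bears on the reason for this result.

What the compounds shown leave open is whether any group at this place can move the number beyond the scatter, since an aminoethyl chain, a carboxylic acid or a phenyl ring on the same nitrogen would test a different kind of group from the carbon chains and ring seen so far. They also share the rest of the core, so they leave open how much a change elsewhere in the molecule would matter compared with a change at this place.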